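Opening the ring on a weak amine side chain

This account rests on a few compounds, and the source may have more. Where it says the series, first, only, none or still open, it means among the compounds named here.

In a functional assay on MCF7 cells (Homo sapiens) for antiproliferative activity (a higher number here means a weaker inhibitor, a lower number a stronger inhibitor), compound 1 `CC(=O)Oc1ccc(C(=O)Nc2cc3ccc(OCC4CCCN(C)C4)c(C)c3oc2=O)cc1CC=C(C)C` gives a measured value of 1650 nM. Compound 2 `CC(C)=CCc1cc(C(=O)Nc2cc3ccc(OCCCN4CCCCC4)c(C)c3oc2=O)ccc1O` gives > 50000 nM, and this is a limit of the assay and not a number. Compound 2 therefore stands at the limit of > 50000 nM in this assay, at which 1 of the 2 values shown sits, with no exact potency to serve as a starting point.

Compound 3 `CCN(CC)CCCOc1ccc2cc(NC(=O)c3ccc(O)c(CC=C(C)C)c3)c(=O)oc2c1C` differs from compound 2 in a single place: diethylamino in place of piperidin-1-yl on a saturated chain carbon, three bonds along the chain from an oxygen on an aromatic ring. The diethylamino group takes the place of piperidin-1-yl on a saturated chain carbon, three bonds along the chain from an oxygen on an aromatic ring. Among the compounds with values here, no measured pair in this small set shows what such a swap does in this assay, so its size has to be judged from the change itself. The change keeps the basic outline of the side chain and replaces a ring with two open chains, so only a modest shift is expected, perhaps slightly toward a stronger inhibitor. The expected change is an at least 1.6-fold lower number from compound 2 to compound 3 (0.22 log units; that floor lies within the scatter), and a further limit reading would not be surprising. For compound 3 the estimated value is 30000 nM, with an expected range from 5000 nM to 80000 nM.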

Compound 3, half-maximal inhibitory concentration: 6390 nM
For compound 3 the middle estimate is 4.7-fold (0.67 log units) above the measured one; the measured number falls inside the stated range.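

Compound 3 gives this side chain an exact number. In this assay, the change to diethylamino in place of piperidin-1-yl, on a saturated chain carbon, three bonds along the chain from an oxygen on an aromatic ring, gives an at least 7.8-fold lower number from compound 2 to compound 3 (0.89 log units; beyond the scatter). The change from 3-(piperidin-1-yl)propyl to 3-(diethylamino)propyl is thus enough, with the rest of the structure unchanged, to move the reading from a limit to a measured value, but the true size of the step remains unknown because only a floor can be read from compound 2: the limit of > 50000 nM in this assay, at which 1 of the 3 values shown sits.

As far as these compounds go, what a dimethylamino group, a morpholin-4-yl ring or a longer chain between the oxygen and the amine would do in this place remains open, so the two compounds cannot show whether opening the ring matters in itself or whether other amines would read the same way. From the compounds shown here alone, it is also open whether the same swap would give a step of similar size in a compound carrying the acetate ester seen in compound 1 instead of the free hydroxyl group.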